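The source may hold more compounds than are shown below. What is called first, only, known or untested is meant among the compounds shown, and "the series" means these compounds.

Working notes on the series. Compound 1 `COC(=O)[C@H](O)[C@H]1C(=O)N2C(C(=O)O)=C(C(C)(C)C)O[C@H]12` and compound 2 `Cn1cc([C@H](O)[C@H]2C(=O)N3C(C(=O)O)=C(C(C)(C)C)O[C@H]23)nn1` share the same core and differ at a single position. In an ADME assay, in phosphate buffer, at 28 degrees C, at pH 7.0 (a higher number here means that the compound lasts longer, a lower number that the compound disappears faster), compound 1 gives 6.7 h, and in this assay compound 2 gives 7 h. Among the compounds with values here, the step of a 1.0-fold higher number from compound 1 to compound 2 (0.02 log units; within the scatter) is the only measured step in the set so far; compound 2 sits within the scatter of compound 1, so no order between the two can be claimed, and compound 2 is simply one of two numbers lying together.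

Compound 3 `CC(C)(C)C1=C(C(=O)O)N2C(=O)[C@H]([C@@H](O)CCc3ccccc3)[C@H]2O1` has not yet been measured. It differs from compound 2 by phenethyl in place of 1-methyl-1H-1,2,3-triazol-4-yl on a saturated chain carbon bound to an oxygen on a saturated carbon and a saturated ring carbon. Within the data shown here, the one step that bears on this change is a 1.0-fold higher number from compound 1 to compound 2 (0.02 log units; within the scatter), which exchanged the group at the same place without moving the half-life beyond the scatter. Among the measured compounds shown here, no measured step brings in a phenethyl or any six-membered aromatic ring of carbon only, so the data give nothing to point in either direction. The working expectation for compound 3 is therefore a step of no change at the digits printed from compound 2 to compound 3 (within the scatter), none beyond the scatter. For compound 3 in this assay the estimate is 7 h, with a range from 3.5 h to 14 h.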

Compound 3, half-life: 39 h
Estimate against measurement, compound 3: 5.6-fold (0.75 log units) below; the measured number lies above the stated range.
By their numbers in this assay, from the lowest: compounds 1 and 2 (each within the scatter of the next); then compound 3.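

In this assay, the group on this saturated chain carbon can matter: phenethyl in place of 1-methyl-1H-1,2,3-triazol-4-yl gives a 5.6-fold higher number from compound 2 to compound 3 (0.75 log units; beyond the scatter), and phenethyl in place of methoxycarbonyl gives a 5.8-fold higher number from compound 1 to compound 3 (0.76 log units; beyond the scatter). The only earlier exchange at this place, a 1.0-fold higher number from compound 1 to compound 2 (0.02 log units; within the scatter), had shown no more than that those two groups lie together, whereas the two steps to phenethyl now show that the half-life at this place can move beyond the scatter, with a step of similar size whichever of the two groups leaves. Nothing available explains why phenethyl stands apart from the other two groups.

Going by these compounds, with only these three compounds, the six-membered aromatic ring of carbon only cannot be separated from the chain that carries it, so it remains open whether the higher half-life follows the ring, the chain or the whole phenethyl group. A benzyl or a phenyl group, a saturated chain such as n-butyl, or a 2-cyclohexylethyl group at this place would separate these parts, and a phenethyl group carrying an amine or a carboxylic acid on its ring would test how much change the group tolerates.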